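The compounds below may be only part of what the source reports. "The series", "measured", "known", "first", "only" and "open" are said of these compounds alone.

Of the compounds shown here, three have so far been measured in a functional assay on HCT-116 cells (Homo sapiens) for cytotoxicity, with a stated time of 3 days; on this read-out lower numbers stand for stronger inhibition and higher numbers for weaker inhibition. Compound 1 `CC#CC1=Nc2ccccc2C(C)(C)O1` gives only a limit of the assay, > 40000 nM. Compound 2 `C#Cc1nc2ccccc2s1` gives 19600 nM in this assay. Compound 3 `CC#Cc1nc2ccccc2s1` also gives only a limit, > 40000 nM. The difference between the core of compound 1 and the core of compound 3 is not broken down here. Within the core of compound 3, the change hydrogen in place of methyl on a triple-bonded carbon brought an at least 2.0-fold lower number from compound 3 to compound 2 (0.30 log units; that floor lies within the scatter), and the floor of that step arises because of the limit of > 40000 nM in this assay, at which 2 of the 3 values shown sit. Compound 4 `C#CC1=Nc2ccccc2C(C)(C)O1`, not yet measured, carries the same change made on compound 1: hydrogen in place of methyl on a triple-bonded carbon. The step of an at least 1.1-fold lower number from compound 1 to compound 4 (0.05 log units; that floor lies within the scatter) is expected, resting on an at least 2.0-fold lower number from compound 3 to compound 2 (0.30 log units; that floor lies within the scatter). Compound 4 is therefore estimated to give about 35000 nM in this assay, with a real chance that only a limit is again reported.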

Compound 4, half-maximal inhibitory concentration: 5610 nM
Beside the measured number, compound 4's estimate is 6.2-fold (0.80 log units) above it; measured number below the stated range.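

Replacing prop-1-yn-1-yl with ethynyl gave, in this assay, an at least 7.1-fold lower number from compound 1 to compound 4 (0.85 log units; beyond the scatter), so on this core the change clearly lowers the number. This shows that the change carries over in direction, but not that it carries over with the same size, as the comparison of the two cores reaches only this far: the same change on two cores in this assay, an at least 2.0-fold lower number (0.30 log units; that floor lies within the scatter) from compound 3 to compound 2 and an at least 7.1-fold lower number (0.85 log units; beyond the scatter) from compound 1 to compound 4; the limit leaves it open whether they differ. Both steps are floors rather than exact sizes, because compound 1 and compound 3 each give only a limit of the assay: the limit of > 40000 nM in this assay, at which 2 of the 4 values shown sit.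

The compounds shown leave open how the number responds when the hydrogen on the triple-bonded carbon gives way to a longer chain or to a chain ending in an amine. They also leave open whether the change behaves alike on any third core.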